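The source may report more compounds than this note shows. Statements on the series, on what has been measured and on what is new or still open speak of the compounds shown alone.

Measured in a functional assay on CHO-K1 cells for antagonist activity at prostaglandin E2 receptor EP1 subtype (Homo sapiens), read by FLIPR; a lower number here means a stronger inhibitor, a higher number a weaker inhibitor:
compound 1 `Cc1cc(C(=O)O)nn1Cc1cc(Br)ccc1OCc1ccccc1` gives 15.1 nM
compound 2 `Cc1cc(C(=O)O)nn1Cc1cc(Br)ccc1OCc1c(F)cccc1F` gives 105 nM

Among the two numbers, compound 2 stands highest; its nearest neighbour is compound 1, and the step of a 7.0-fold higher number from compound 1 to compound 2 (0.84 log units; beyond the scatter) lies beyond the scatter. Compound 3 `Cc1cc(C(=O)O)nn1Cc1cc(Br)ccc1OCc1cccc([N+](=O)[O-])c1` has not yet been measured. Its difference from compound 2 is 3-nitrophenyl in place of 2,6-difluorophenyl on a saturated chain carbon bound to an oxygen on an aromatic ring. Within the data shown here, no measured step covers this exchange directly. Among the measured compounds shown here, the one step on record, a 7.0-fold higher number from compound 1 to compound 2 (0.84 log units; beyond the scatter), shows only that swapping the aromatic ring on the saturated chain carbon bound to the oxygen on the aromatic ring can move the number by a modest, but real, amount. On this basis a modest shift in this assay is expected for compound 3, most likely back toward the number of compound 1, though with wide uncertainty in either direction. For compound 3 the estimate is 40 nM, expected between 8 nM and 200 nM, corresponding to an expected step of a 2.6-fold lower number from compound 2 to compound 3 (0.42 log units; beyond the scatter).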

Compound 3, inhibition constant: 339 nM
Estimate against measurement, compound 3: 8.5-fold (0.93 log units) below, and the stated range ends below it.
By their numbers in this assay, from the lowest: compound 1; then compound 2; then compound 3.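

In this assay a second substituted ring at this place, on a saturated chain carbon bound to an oxygen on an aromatic ring, also fails to match the unsubstituted phenyl: nitro in place of hydrogen on an aromatic carbon gives a 22-fold higher number from compound 1 to compound 3 (1.35 log units; beyond the scatter) and is a large change. Exchanging 2,6-difluorophenyl for 3-nitrophenyl gives a 3.2-fold higher number from compound 2 to compound 3 (0.51 log units; beyond the scatter) and so does not recover the number of compound 1, which remains the lowest of the three with both of the other compounds beyond the scatter from it. Nothing available explains these steps.

The three compounds leave open whether any substituent on this ring can match plain phenyl. On these data alone, an amine or a carboxylic acid in place of the nitro remains untested here, as does a longer chain between the ring and the oxygen.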